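From carboxymethoxy to 2-carboxyethenyl on the shared core

The compounds below may be only part of what the source reports. "The series", "measured", "known", "first", "only" and "open" are said of these compounds alone.

Four compounds share one core: compound 1 (`CNC(=O)/C=C/c1ccncc1-c1ccc2ccccc2c1`), compound 2 (`NNC(=O)CCc1ccncc1-c1ccc2ccccc2c1`), compound 3 (`O=C(O)COc1ccncc1-c1ccc2ccccc2c1`) and compound 4 (`O=C(O)/C=C/c1ccncc1-c1ccc2ccccc2c1`). In a functional assay on HCT-116 cells (Homo sapiens) for inhibition, read by MTT assay, with a stated time of 72 h (on this read-out lower numbers stand for stronger inhibition of growth and higher numbers for weaker inhibition of growth), compound 1 gives 6550 nM. Compound 2 reaches only a limit of the measurement, > 30000 nM. The top of the scale for this small set is therefore (the limit of > 30000 nM in this assay, at which 1 of the 3 values shown sits). Compound 3 has no number on this scale, and its result reads "not determined" (no result reported).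

Compound 4 differs from compound 3 as follows: 2-carboxyethenyl in place of carboxymethoxy on an aromatic carbon. It carries 2-carboxyethenyl in place of carboxymethoxy on an aromatic carbon, opposite the ring nitrogen. Among the compounds with values here, only one measured step is available, an at least 4.5-fold higher number from compound 1 to compound 2 (0.66 log units; beyond the scatter), with 2-(aminocarbamoyl)ethyl in place of 2-(methylcarbamoyl)ethenyl. It lies beyond the scatter, but it concerns other groups and gives only loose guidance. Within the data shown here, with no number for compound 3, no size of step from it can be expected in this assay. Among the measured compounds shown here, the expectation instead starts from compound 1 at 6550 nM and leans towards weaker inhibition of growth, the direction of the one measured step. For compound 4 the expected value is about 20000 nM, with an estimated range from 7000 nM to 45000 nM.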

Compound 4, concentration for 50% growth inhibition: > 30000 nM
Compound 4 ended at the assay's limit; the forecaster's own chance of this, stated with the estimate: 45%; at least 1.5-fold (0.17 log units) between middle value and limit.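

At the position opposite the ring nitrogen, hydroxy in place of methylamino on a carbonyl carbon, with the ethenyl link kept, gives an at least 4.5-fold higher number from compound 1 to compound 4 (0.66 log units; beyond the scatter) in this assay and so changes only the end of the chain. The earlier step changed the link as well, whereas this one shows that a change at the carbonyl end alone is enough to weaken inhibition of growth beyond the scatter. Compound 4 gives > 30000 nM in this assay, which is a limit and not a number, so its step from compound 2, which also stands at a limit, cannot be read, and the top of the scale now holds two compounds: the limit of > 30000 nM in this assay, at which 2 of the 4 values shown sit.

As far as these compounds go, with no result for compound 3, the shared core gives no comparison between carboxymethoxy and 2-carboxyethenyl at this position, and how far compound 4 lies past its limit also stays open. Whether a primary amide, a methyl ester or an amine at the end of the ethenyl chain, or a longer chain ending in the methylamide, would keep or strengthen inhibition of growth relative to compound 1 is also unresolved.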